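This account rests on a few compounds, and the source may have more. Where it says the series, first, only, none or still open, it means among the compounds named here.

Three compounds have been measured so far:
compound 1, `CCCCCCCCCCn1cc(-c2nc3ccccc3cc2CCCC)nn1`, 25.2 ug/mL
compound 2, `CCc1cc2ccccc2nc1-c1cn(CCC(F)(F)C(F)(F)C(F)(F)C(F)(F)C(F)(F)C(F)(F)C(F)(F)C(F)(F)F)nn1`, 55.9 ug/mL
compound 3, `CCCCCc1cc2ccccc2nc1-c1cn(-c2ccc(F)cc2)nn1`, 67.5 ug/mL

All three were tested in a functional assay on U-937 cells (Homo sapiens) for cytotoxicity, read by MTT assay, with a stated time of 24 h; a lower number here means a stronger inhibitor, a higher number a weaker inhibitor. Compound 2 gives 55.9 ug/mL, which is the second highest of the three numbers. The nearest of the others is compound 3, whose 67.5 ug/mL lies within the usual scatter of compound 2, so the two cannot be told apart. The furthest is compound 1, whose 25.2 ug/mL is a lower number and lies beyond the scatter, which makes compound 1 the stronger inhibitor of that pair.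

The next compound, compound 4 `Cc1cc2ccccc2nc1-c1cn(CCC(F)(F)C(F)(F)C(F)(F)C(F)(F)C(F)(F)C(F)(F)C(F)(F)C(F)(F)F)nn1`, differs from compound 2 in one place: hydrogen in place of methyl on a saturated chain carbon bound to an aromatic carbon. The 3-ethylquinolin-2-yl of compound 2 becomes 3-methylquinolin-2-yl in compound 4, while the long fluorinated chain stays as it is. Among the measured compounds shown here, no pair of measured compounds differing in just one place is available, so there is nothing to lean on for this particular change. The loss of a methyl is a small change, and in this assay the step of a 1.0-fold lower number from compound 2 to compound 4 (0.01 log units; within the scatter) is expected to be small, in no direction beyond the scatter. On that basis the estimate for compound 4 is 55 ug/mL, with a range from 28 ug/mL to 110 ug/mL.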

Compound 4, half-maximal inhibitory concentration: 56.6 ug/mL
Compound 4: middle estimate off by 1.0-fold (0.01 log units), on the low side; the measured number falls inside the stated range.
By their numbers in this assay, from the lowest: compound 1; then compounds 2, 4 and 3 (each within the scatter of the next).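

Among the compounds shown here, compound 2 and compound 4 are the only pair here that differ in one place, and in this assay the step is a 1.0-fold higher number from compound 2 to compound 4 (0.01 log units; within the scatter). This shows that on this saturated chain carbon bound to an aromatic carbon, putting hydrogen in place of methyl leaves the number within the usual scatter, so 3-ethylquinolin-2-yl and 3-methylquinolin-2-yl cannot be told apart while the long fluorinated chain stays as it is. No measurement shown here offers an explanation for this result.

On these data alone, this single pair covers only a small change, so it remains open whether a different kind of group in this place, such as an amine or a carboxylic acid, would move the number beyond the scatter. As far as these compounds go, it also remains open whether the change from ethyl to methyl would give a similarly small step if another group stood in place of the long fluorinated chain.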